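Replacing the Difluorophenyl of Compound 3 with a Hydroxypropyl Chain

The compounds below may be only part of what the source reports. "The series", "measured", "known", "first", "only" and "open" are said of these compounds alone.

Measured compounds:
compound 1, `COc1cnc(-c2ccccn2)nc1N(C)C1CCCC1`: 180 nM
compound 2, `COc1cnc(-c2ccccn2)nc1NCc1ccccc1F`: 130 nM
compound 3, `COc1cnc(-c2ccccn2)nc1NCc1ccc(F)cc1F`: 110 nM

All three were tested in a functional assay on RAW264.7 cells (Mus musculus), with a stated time of 3 days; a lower number here means a stronger inhibitor, a higher number a weaker inhibitor. Among the compounds with values here, the one step among them, a 1.2-fold lower number from compound 2 to compound 3 (0.07 log units; within the scatter), lies within the scatter. Compound 1 gives 180 nM where compound 3 gives 110 nM, and that gap too is within the scatter; on these numbers the three compounds cannot be separated.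

Compound 4, `COc1cnc(-c2ccccn2)nc1NCCCCO`, differs from compound 3 by 3-hydroxypropyl in place of 2,4-difluorophenyl on a saturated chain carbon bound to a nitrogen on an aromatic ring. Within the data shown here, the only step between measured compounds, a 1.2-fold lower number from compound 2 to compound 3 (0.07 log units; within the scatter), adds a fluoro to an aromatic ring that stays in place; it does not speak to removing that ring altogether. Compound 1 carries a cyclopentyl on a methylated nitrogen and gives no guidance on an open chain bearing a hydroxyl either. Among the measured compounds shown here, no measured step therefore bears on this change, and the expectation rests on the size of the change alone: a whole aromatic ring leaves and a short chain enters.

Compound 4 is expected to give a higher number, with a step of a 5.5-fold higher number from compound 3 to compound 4 (0.74 log units; beyond the scatter), and its estimate in this assay is 600 nM, within a range of 150 nM to 3000 nM.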

Compound 4, half-maximal inhibitory concentration: 3000 nM
For compound 4 the middle estimate is 5.0-fold (0.70 log units) below the measured one, and the stated range covers the measured number.
By their numbers in this assay, from the lowest: compounds 3, 2 and 1 (each within the scatter of the next); then compound 4.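

In this assay, within the data shown here, the earlier compounds could not be separated, but this change can: the step is large, with a 27-fold higher number from compound 3 to compound 4 (1.44 log units; beyond the scatter), and it is matched by a 23-fold higher number from compound 2 to compound 4 (1.36 log units; beyond the scatter). The position, on a saturated chain carbon bound to a nitrogen on an aromatic ring, therefore responds strongly to the group it carries, far more than to the added fluoro (a 1.2-fold lower number from compound 2 to compound 3 (0.07 log units; within the scatter)), and the saturated cyclopentyl(methyl)amino group of compound 1 also stands well apart from the (4-hydroxybutyl)amino group, with a 17-fold higher number from compound 1 to compound 4 (1.22 log units; beyond the scatter), so among these four compounds only the one with no ring in this group gives the high number. Nothing shown here explains this rise.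

On these data alone, compound 4 loses the ring and gains the hydroxyl in one step, so the share of each in the rise stays open. A plain butyl chain with no hydroxyl, a chain ending in a methoxy group or an amine, and a cyclohexylmethyl group in the same place would each help to separate the two.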